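Adding a second chloro to the benzyl group

The source may hold more compounds than are shown below. What is called first, only, known or untested is meant among the compounds shown, and "the series" means these compounds.

Measured in a functional assay on A549 cells (Homo sapiens) for cytotoxicity, read by MTT assay, with a stated time of 72 h; on this read-out lower numbers stand for stronger inhibition and higher numbers for weaker inhibition:
- compound 1 `CN(C)Cc1ccc2nc(NC(=O)N/N=C/c3cn(Cc4ccc(C(C)(C)C)cc4)c4ccccc34)sc2c1`: 1850 nM
- compound 2 `CN(C)Cc1ccc2nc(NC(=O)N/N=C/c3cn(Cc4ccc(Cl)cc4)c4ccccc34)sc2c1`: 840 nM

For the measured compounds named here, compound 2 holds the lower of the two measured numbers, and its only neighbour is compound 1, with a 2.2-fold lower number from compound 1 to compound 2 (0.34 log units; beyond the scatter). Compound 3 `CN(C)Cc1ccc2nc(NC(=O)N/N=C/c3cn(Cc4ccc(Cl)c(Cl)c4)c4ccccc34)sc2c1` differs from compound 2 by one change: chloro in place of hydrogen on an aromatic carbon. This is chloro in place of hydrogen on an aromatic carbon, which turns 4-chlorobenzyl into 3,4-dichlorobenzyl.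

Going by the values given here, only one measured step bears on this change, the modest one in which chloro replaces tert-butyl on an aromatic carbon. It is a loose guide, since that step exchanges one group for another, whereas here a chloro is added and the hydrogen goes. Among the compounds with values here, no measured compound carries a second chloro. A small step in this assay is therefore expected, no larger than the modest one already seen and leaning towards a lower number, and it may well stay within the scatter. The estimated step is a 1.3-fold lower number from compound 2 to compound 3 (0.11 log units; within the scatter). For compound 3 the expected value is 650 nM, with an estimated range of 280 nM to 1500 nM.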

Compound 3, half-maximal inhibitory concentration: 940 nM
For compound 3 the middle estimate is 1.4-fold (0.16 log units) below the measured one, and the stated range covers the measured number.
By their numbers in this assay, from the lowest: compounds 2, 3 and 1 (each within the scatter of the next, the first and the last beyond it).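

In this assay, the first direct test of this position is the chloro added ortho to the existing chloro group, and it gives a 1.1-fold higher number from compound 2 to compound 3 (0.05 log units; within the scatter), so 4-chlorobenzyl and 3,4-dichlorobenzyl cannot be told apart on this read-out. Against the tert-butyl end of the set the comparison gives a 2.0-fold lower number from compound 1 to compound 3 (0.29 log units; within the scatter), which leaves compound 3 within the scatter of compound 1 as well, even though the step between compound 1 and compound 2 is printed as beyond it, so the three benzyl groups do not fall into clean separate levels. No supporting data are available to explain why the second chloro leaves the number where it is.

Still open, as far as these compounds go, is whether this flat response is particular to chloro, or whether a fluoro, a methoxy group or a carboxylic acid on the same aromatic carbon would also stay within the scatter of compound 2. Also open, from the compounds shown here alone, is whether an amine on that ring, or a longer chain in place of the benzyl group, would move the number beyond the narrow band that these three compounds occupy.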